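Trifluorophenyl in place of aminomethoxyphenyl on the cinnamamide chain

A few compounds are considered here, and "the series" means these few. Any claim that something is new, unique, unknown or untested is made for them only; others in the source may bear on it.

Three benzophenone cinnamamides share one core and differ only in the aryl ring on a double-bonded chain carbon bound to a double-bonded chain carbon. Compound 1 `COc1cc(C(=O)c2cc(OC)c(OC)c(OC)c2)cc(NC(=O)/C=C/c2cc(OC)c(OC)c(OC)c2)c1OC` carries a 3,4,5-trimethoxyphenyl there and in a functional assay on PC-3 cells (Homo sapiens) for cytotoxicity, read by MTT assay, with a stated time of 72 h (on this read-out higher numbers stand for weaker inhibition and lower numbers for stronger inhibition), compound 1 gives 4800 nM. Compound 2 `COc1cccc(/C=C/C(=O)Nc2cc(C(=O)c3cc(OC)c(OC)c(OC)c3)cc(OC)c2OC)c1` carries a 3-methoxyphenyl and in this assay compound 2 gives 13300 nM. Compound 3 `COc1ccc(/C=C/C(=O)Nc2cc(C(=O)c3cc(OC)c(OC)c(OC)c3)cc(OC)c2OC)cc1N` carries a 3-amino-4-methoxyphenyl and in this assay compound 3 gives 11100 nM. Compound 3 thus stands second highest of the three: its nearest neighbour is compound 2, a step of a 1.2-fold lower number from compound 2 to compound 3 (0.08 log units; within the scatter) that lies within the scatter, and the step of a 2.3-fold higher number from compound 1 to compound 3 (0.36 log units; beyond the scatter) lies beyond it, as does a 2.8-fold higher number from compound 1 to compound 2 (0.44 log units; beyond the scatter).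

Compound 4 `COc1cc(C(=O)c2cc(OC)c(OC)c(OC)c2)cc(NC(=O)/C=C/c2cc(F)c(F)c(F)c2)c1OC` is the next step from compound 3: 3,4,5-trifluorophenyl in place of 3-amino-4-methoxyphenyl on a double-bonded chain carbon bound to a double-bonded chain carbon. Going by the values given here, no measured step covers a trifluorophenyl; the two steps that bear on this position show only that any ring other than 3,4,5-trimethoxyphenyl raised the number modestly, while the two alternatives tried sit within the scatter of each other. He therefore expects a step of a 1.1-fold higher number from compound 3 to compound 4 (0.03 log units; within the scatter) that is small and uncertain in direction. His estimate for compound 4 in this assay is 12000 nM, within 4000 nM to 40000 nM.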

Compound 4, half-maximal inhibitory concentration: 7400 nM
Beside the measured number, compound 4's estimate is 1.6-fold (0.21 log units) above it; measured number inside the range.
By their numbers in this assay, from the lowest: compounds 1, 4, 3 and 2 (each within the scatter of the next, the first and the last beyond it).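

In this assay, the 3,4,5-trifluorophenyl ring differs from the 3-methoxyphenyl and 3-amino-4-methoxyphenyl rings in that its step from the 3,4,5-trimethoxyphenyl ring stays within the scatter (a 1.5-fold higher number from compound 1 to compound 4 (0.19 log units; within the scatter)), so giving up that ring does not cost a step beyond the scatter for every replacement. Compound 4 also stays within the scatter of the other two replacements (a 1.5-fold lower number from compound 3 to compound 4 (0.18 log units; within the scatter) and a 1.8-fold lower number from compound 2 to compound 4 (0.25 log units; within the scatter)), although 3,4,5-trifluorophenyl has no hydrogen-bond donors or acceptors and 3-amino-4-methoxyphenyl has both. Nothing available explains these numbers.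

The four compounds span too little to rank the three replacements at this position. From the compounds shown here alone, whether a carboxylic acid or a hydroxyl on this ring, or a longer chain in place of the ethenyl link, would move the number beyond the scatter remains open.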